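Adding a tosyl-type sulfonyl to the amino group of compound 1

A few compounds are considered here, and "the series" means these few. Any claim that something is new, unique, unknown or untested is made for them only; others in the source may bear on it.

Compound 1, with structure `Nc1ccc(CNC(=O)CC2c3ccccc3N=C(N3CCCCC3)N2c2ccccc2)cc1`, was tested in a functional assay on SK-OV-3 cells (Homo sapiens) for inhibition, read by sulforhodamine B assay (a lower number here means a stronger inhibitor of growth, a higher number a weaker inhibitor of growth), and gave 39300 nM. Among the three compounds measured, it stands with the second highest number. Compound 3 `CCN1C(N(C)C)=Nc2ccccc2C1CC(=O)NCc1ccc(NS(=O)(=O)c2ccc(F)cc2)cc1` gives 46500 nM, a reading that lies within the scatter of compound 1. Compound 2 `COC(=O)CC1c2ccccc2N=C(NCCCCCN)N1c1ccc(-c2ccccc2)cc1` gives 3240 nM, which is beyond the scatter and marks a clearly stronger inhibitor of growth than compound 1.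

Compound 4 `Cc1ccc(S(=O)(=O)Nc2ccc(CNC(=O)CC3c4ccccc4N=C(N4CCCCC4)N3c3ccccc3)cc2)cc1` is derived from compound 1 by a single change: (4-methylphenyl)sulfonyl in place of hydrogen on a nitrogen on an aromatic ring. Among the compounds with values here, no pair of measured compounds shows this exact change, so the direction of the step can only be guessed from the values at hand. Compound 4 is expected to give a number in this assay close to that of compound 1, with a step of a 1.3-fold lower number from compound 1 to compound 4 (0.12 log units; within the scatter) that is not expected to go beyond the scatter, because compound 3 gives 46500 nM in the same weak region. Compound 4 is thus estimated at 30000 nM, with a range from 10000 nM to 90000 nM.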

Compound 4, concentration for 50% growth inhibition: 2930 nM
Beside the measured number, compound 4's estimate is 10-fold (1.01 log units) above it; the whole stated range lies above it.
By their numbers in this assay, from the lowest: compounds 4 and 2 (each within the scatter of the next); then compounds 1 and 3 (each within the scatter of the next).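

On a nitrogen on an aromatic ring, going from amino to ((4-methylphenyl)sulfonyl)amino gives in this assay a step of a 13-fold lower number from compound 1 to compound 4 (1.13 log units; beyond the scatter). Within the data shown here, this is the first step that can be read, as no two of the earlier compounds differed in only one place. It shows that this nitrogen is a position where a single change can move the number well beyond the scatter, and that the free amino group is not needed for growth inhibition in these cells. Nothing available accounts for the size of this step.

Going by these compounds, it remains open whether the whole (4-methylphenyl)sulfonyl group is needed, or whether a smaller methylsulfonyl or an acetyl on the same nitrogen would give a similar step. On these data alone, it is also open whether the step would carry over to a core other than that of compound 1.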